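Swapping a Thiourea Tail for a Methylpiperazine Ring

The source may report more compounds than this note shows. Statements on the series, on what has been measured and on what is new or still open speak of the compounds shown alone.

In a functional assay on SK-MEL-28 cells (Homo sapiens) for cytotoxicity, read by MTT assay, with a stated time of 3 days (a higher number here means a weaker inhibitor, a lower number a stronger inhibitor), compound 1 `N#Cc1c(Nc2ccccc2)nc(SCc2nc3ccccc3[nH]2)nc1-c1ccccc1` gives 8.9 nM. For the measured compounds named here, compound 2 `N#Cc1c(NNC(N)=S)nc(SCc2nc3ccccc3[nH]2)nc1-c1ccccc1` gives 3.2 nM in this assay, the lowest of the two numbers measured so far; the only other, compound 1, stands a 2.8-fold lower number from compound 1 to compound 2 (0.44 log units; beyond the scatter). Compound 3 `CN1CCN(c2nc(SCc3nc4ccccc4[nH]3)nc(-c3ccccc3)c2C#N)CC1` has not yet been measured. It differs from compound 2 in one place: a group of 7 heavy atoms (5 carbon, 2 nitrogen; one six-membered non-aromatic ring with 2 hetero atoms) in place of a group of 5 heavy atoms (1 carbon, 3 nitrogen, 1 sulfur; no ring), on an aromatic carbon. Going by the values given here, the only measured step that touches this part of the shared core is the one in which a thiourea-bearing chain took the place of a phenyl ring on a nitrogen on an aromatic ring, and it moved the number a 2.8-fold lower number from compound 1 to compound 2 (0.44 log units; beyond the scatter), a modest change for a sizeable swap. The present change is bigger: the leaving group's hydrogen-bond donors are lost, and a non-aromatic ring replaces an open chain. Among the compounds with values here, with only one related step to lean on, a modest move in this assay is expected, more likely toward a higher number. Compound 3 is therefore expected to give 15 nM, somewhere between 4 nM and 60 nM, which amounts to an expected 4.7-fold higher number from compound 2 to compound 3 (0.67 log units; beyond the scatter).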

Compound 3, half-maximal inhibitory concentration: 20 nM
Estimate against measurement, compound 3: 1.3-fold (0.12 log units) below; the range from low to high includes it.
By their numbers in this assay, from the lowest: compound 2; then compound 1; then compound 3.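

Measured against the thiourea-bearing chain, 4-methylpiperazin-1-yl gives a 6.3-fold higher number from compound 2 to compound 3 (0.80 log units; beyond the scatter) in this assay and, measured against anilino, it gives a 2.2-fold higher number from compound 1 to compound 3 (0.35 log units; beyond the scatter) so the ring puts compound 3 highest of the three, with both steps beyond the usual scatter. For the compounds shown here, the earlier step showed only that one open group could lower the number; this result shows that the aromatic carbon ortho to a cyano group can also move the number upward, although compound 3 still gives 20 nM as a value in the low nanomolar range. No measurement at hand says why the three groups fall in this order.

The groups at this position differ in size, in ring content and in hydrogen-bond donors all at once, so the compounds shown cannot separate what each of these features contributes to the number. A piperazine ring without its methyl group, a morpholine ring or an open dimethylamino group on the same carbon would take these features apart one at a time.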